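The source may hold more compounds than are shown below. What is called first, only, known or untested is meant among the compounds shown, and "the series" means these compounds.

Compounds measured in a functional assay for activation of Alpha-1D adrenergic receptor (Homo sapiens), read by calcium flux; a higher number here means that more compound is needed for the effect, a lower number that less compound is needed:

Compound 1 `c1ccc(-c2ccncc2)c(OCC2=NCCN2)c1` gives < 100000 nM, a limit of the assay.
Compound 2 `c1ccc(-c2ccncn2)c(OCC2=NCCN2)c1` gives < 100000 nM, a limit of the assay.
Compound 3 `Cc1ccc(-c2ccccc2OCC2=NCCN2)s1` gives < 100000 nM, a limit of the assay.

Compound 3 stands, in this assay, only at a limit, and the two other values shown are limits as well (the limit of < 100000 nM in this assay, at which 3 of the 3 values shown sit). The step from compound 3 to compound 4 `Cc1csc(-c2ccccc2OCC2=NCCN2)n1` is 4-methyl-1,3-thiazol-2-yl in place of 5-methylthiophen-2-yl on an aromatic carbon. The measured steps that touch compound 3 are a step that the two limits leave unreadable from compound 1 to compound 3 and a step that the two limits leave unreadable from compound 2 to compound 3, and the remaining step between measured compounds is a step that the two limits leave unreadable from compound 1 to compound 2; none of them can be read in size, so none gives a direction for the change into compound 4. What the data do show is that every compound of this shared core so far reaches only a limit in this assay, and compound 4 is expected to behave in the same way, with a step that the limit leaves unreadable from compound 3 to compound 4 that is an estimate rather than a reading. For compound 4 the expected value in this assay is therefore 30000 nM, with a range from 3000 nM to 100000 nM, and a high chance that only a limit is reported again.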

Compound 4, half-maximal effective concentration: < 100000 nM
Compound 4: a limit, no number; the forecaster's own chance of this, stated with the estimate: 70%; the middle value is on the limit's open side.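

In this assay compound 4 gives < 100000 nM, a limit of the assay. None of the steps joining compound 4 to compound 1, compound 2 and compound 3 can be read in size. The compounds shown leave open whether these groups on the shared core differ at all, with every value at one limit: the limit of < 100000 nM in this assay, at which 4 of the 4 values shown sit.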